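Chloro for Methoxy on a Shared Bicyclic Core

The source may report more compounds than this note shows. Statements on the series, on what has been measured and on what is new or still open speak of the compounds shown alone.

Of the compounds shown here, three built on one shared core have been measured in a functional assay on the whole organism for inhibition, with Rattus norvegicus as the target, at a dose of 30 mg/kg; a lower number here means less inhibition, a higher number more inhibition at the dose given (going by the name of the read-out). Compound 1 `Clc1ccccc1-c1nc2ncccc2o1` gives 38%, compound 2 `COc1ccccc1-c1nc2ncccc2o1` gives 9%, and compound 3 `COc1ccc(-c2nc3cccnc3o2)cc1` gives 29%. Compound 2 and compound 3 carry the same atoms joined differently; the difference between the two is not broken down here. From compound 2 to compound 1 the change is chloro in place of methoxy on an aromatic carbon, and it produced a number 29 percentage points higher from compound 2 to compound 1 (beyond the scatter). Compound 4 `Clc1ccc(-c2nc3cccnc3o2)cc1`, not yet measured, arises from compound 3 by chloro in place of methoxy on an aromatic carbon, the same kind of change but placed para to a group of 9 heavy atoms rather than ortho to it. Because compound 1 reached 38% after that change, compound 4 is expected to rise by about a number 21 percentage points higher from compound 3 to compound 4 (beyond the scatter), estimated at 50% in this assay, within 25% to 75%.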

Compound 4, a percentage reported as inhibition, in the whole organism at one dose (the size of the read-out at that dose, not a potency): 14%
Beside the measured number, compound 4's estimate is 36 percentage points above it; the measured number lies below the stated range.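

In this assay, chloro in place of methoxy, here para to a group of 9 heavy atoms, gave a number 15 percentage points lower from compound 3 to compound 4 (beyond the scatter), so the earlier gain did not carry over to this pair. The same change therefore cannot be treated as transferable between these two pairs in the series: the same change on two cores in this assay, a number 29 percentage points higher (beyond the scatter) from compound 2 to compound 1 and a number 15 percentage points lower (beyond the scatter) from compound 3 to compound 4, 44 percentage points apart, beyond the scatter of two such steps. This does not show what lies behind the difference, and each result rests on a single pair of compounds.

The compounds shown leave open how an amine or a carboxylic acid on the same aromatic carbon would behave. They also leave open whether a further pair carrying chloro in place of methoxy would follow either step.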